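Two Fluorines on the Ketone-Bearing Ring of Compound 3

The source may hold more compounds than are shown below. What is called first, only, known or untested is meant among the compounds shown, and "the series" means these compounds.

Three pyrazole chalcones with a shared core have been tested in a functional assay on CCRF-CEM cells (Homo sapiens) for inhibition, read by sulforhodamine B assay, with a stated time of 48 h; on this read-out higher numbers stand for weaker inhibition of growth and lower numbers for stronger inhibition of growth. Compound 1 `COc1cc(-c2cc(/C=C/C(=O)c3ccc(Cl)c(Cl)c3)[nH]n2)cc(OC)c1OC` gives 2150 nM. Compound 2 `COc1ccc(-c2cc(/C=C/C(=O)c3ccc(N)cc3)[nH]n2)cc1OC` gives 1740 nM. Compound 3 `COc1ccc(C(=O)/C=C/c2cc(-c3cc(OC)c(OC)c(OC)c3)n[nH]2)cc1` gives 1420 nM. All three numbers lie within the usual scatter of one another, so none of the three can be set apart from the rest on this read-out.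

Among the compounds with values here, the single step between compounds that differ in one place is a 1.5-fold lower number from compound 1 to compound 3 (0.18 log units; within the scatter), and it leaves the two compounds indistinguishable within the scatter.

Compound 4 `COc1cc(-c2cc(/C=C/C(=O)c3ccc(F)c(F)c3)[nH]n2)cc(OC)c1OC` has not yet been measured. It differs from compound 3 in one place: 3,4-difluorophenyl in place of 4-methoxyphenyl on a carbonyl carbon. Within the data shown here, the one step that bears on this change is a 1.5-fold lower number from compound 1 to compound 3 (0.18 log units; within the scatter), which shows that exchanging a 4-methoxyphenyl for a dihalogenated phenyl on the carbonyl carbon moved the number only within the scatter. Compound 1, which carries a 3,4-dichlorophenyl at the same place, gives 2150 nM, and compound 3 gives 1420 nM. On this basis a 3,4-difluorophenyl is expected to leave the number near that of compound 3, with at most a modest rise toward compound 1, within the scatter: a 1.3-fold higher number from compound 3 to compound 4 (0.13 log units; within the scatter). Compound 4 is therefore estimated at 1900 nM, with a range from 900 nM to 4000 nM.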

Compound 4, concentration for 50% growth inhibition: 3800 nM
For compound 4 the middle estimate is 2.0-fold (0.30 log units) below the measured one; low and high end bracket the measured number.
By their numbers in this assay, from the lowest: compounds 3, 2, 1 and 4 (each within the scatter of the next, the first and the last beyond it).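

In this assay, the exchange of 4-methoxyphenyl for 3,4-difluorophenyl on the carbonyl carbon gives a 2.7-fold higher number from compound 3 to compound 4 (0.43 log units; beyond the scatter). Within the data shown here, this is the first step at this place that lies beyond the scatter, so the group held here can matter to the number, which the earlier step from compound 1 to compound 3 could not show. Among these compounds, the exchange between the two dihalogenated phenyl groups gives a 1.8-fold higher number from compound 1 to compound 4 (0.25 log units; within the scatter), so 3,4-difluorophenyl and 3,4-dichlorophenyl cannot be told apart on this read-out, and only the pair of compound 3 and compound 4 separates.

No measurement at hand accounts for the step from the 4-methoxyphenyl to the 3,4-difluorophenyl. Still open, going by these compounds, is how a 4-hydroxyphenyl, a 4-trifluoromethylphenyl or an unsubstituted phenyl on the carbonyl carbon would compare with compound 3, and whether the same exchange would give a similar step on the core of compound 2.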